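Swapping the para propargyloxy for fluoro on compound 2

The compounds below may be only part of what the source reports. "The series", "measured", "known", "first", "only" and "open" are said of these compounds alone.

Measured compounds and their numbers:
Compound 1 `C#CCOc1ccc(-c2noc(NC3CCCCC3)n2)cc1` gives 38.3 ug/mL in an ADME assay on RAW264.7 cells (Mus musculus) for cytotoxicity, read by MTT assay, with a stated time of 48 h; on this read-out lower numbers stand for higher toxicity in this test and higher numbers for lower toxicity in this test.
Compound 2 `C#CCOc1ccc(-c2noc(N(CC#C)C3CCCCC3)n2)cc1` gives 101 ug/mL.
Compound 3 `C#CCN(c1nc(-c2cccc([N+](=O)[O-])c2)no1)C1CCCCC1` gives 34.2 ug/mL.

Compound 2 holds the highest number of the three, with compound 1 nearest and compound 3 furthest. Going by the values given here, the one step that differs in a single place is a 2.6-fold higher number from compound 1 to compound 2 (0.42 log units; beyond the scatter), which changes the nitrogen, not the aryl ring, and so does not bear on the move to compound 4 `C#CCN(c1nc(-c2ccc(F)cc2)no1)C1CCCCC1`. That move is fluoro in place of propargyloxy on an aromatic carbon. Among the compounds with values here, no measured step covers this change; compound 3, with a different aryl group, simply shows a lower number than compound 2. On that basis compound 4 is expected to land below compound 2, with an estimated step of a 2.0-fold lower number from compound 2 to compound 4 (0.31 log units; beyond the scatter). The estimate for compound 4 is 50 ug/mL, within 20 ug/mL to 120 ug/mL.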

Compound 4, half-maximal cytotoxic concentration: 20.9 ug/mL
Beside the measured number, compound 4's estimate is 2.4-fold (0.38 log units) above it, and the stated range covers the measured number.
By their numbers in this assay, from the lowest: compounds 4, 3 and 1 (each within the scatter of the next); then compound 2.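

In this assay, going by these compounds alone, fluoro in place of propargyloxy on the aromatic carbon gives a 4.8-fold lower number from compound 2 to compound 4 (0.68 log units; beyond the scatter), the first reading at this position, as the earlier step changed only the nitrogen. With the propargyl on that nitrogen unchanged, this aryl substituent alone shifts the number towards higher toxicity in this test. No measured evidence accounts for this shift. On these data alone, it remains open how an amine or a carboxylic acid at this position would read, and whether the same change would hold with hydrogen on the nitrogen.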